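The compounds below may be only part of what the source reports. "The series", "measured", "known", "first", "only" and "open" are said of these compounds alone.

In a functional assay on PC-3 cells (Homo sapiens) for antiproliferative activity, read by sulforhodamine B assay, with a stated time of 48 h, tested at 50 uM (on this read-out higher numbers stand for more inhibition at the one concentration tested (going by the name of the read-out) and lower numbers for less inhibition), compound 3 `CC1=CC[C@H](C(C)C)c2cc(C)c(OC(=O)c3cccc(Cl)c3)cc21` gives 23.4%, the highest of the three numbers, though its neighbours sit close: compound 2 `CC1=CC[C@H](C(C)C)c2cc(C)c(OC(=O)c3ccccc3)cc21` gives 22.5% and compound 1 `COc1cccc(C(=O)Oc2cc3c(cc2C)[C@@H](C(C)C)CC=C3C)c1` gives 16.3%. The step of a number 0.9 percentage points higher from compound 2 to compound 3 (within the scatter) and the step of a number 7.1 percentage points higher from compound 1 to compound 3 (within the scatter) both stay inside the scatter, as does a number 6.2 percentage points higher from compound 1 to compound 2 (within the scatter). Compound 4 `CC1=CC[C@H](C(C)C)c2cc(C)c(OC(=O)c3cccc(C(F)(F)F)c3)cc21` differs from compound 3 by trifluoromethyl in place of chloro on an aromatic carbon on the aromatic carbon meta to a large group. No measured step involves trifluoromethyl, so only the small movements among compounds 1, 2 and 3 bear on it, and these give no reason to expect a change in this assay beyond the scatter. Compound 4 is therefore expected to show a number 0.6 percentage points higher from compound 3 to compound 4 (within the scatter). The estimate for compound 4 in this assay is 24%, within a range from 12% to 36%.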

Compound 4, a percentage reported as inhibition, at one concentration (the size of the read-out at that concentration, not a potency): 25.4%
Compound 4: the middle estimate sits 1.4 percentage points below what was measured, and the stated range covers the measured number.
By their numbers in this assay, from the lowest: compounds 1, 2, 3 and 4 (each within the scatter of the next).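

In this assay trifluoromethyl on this aromatic carbon gives a number 2 percentage points higher from compound 3 to compound 4 (within the scatter), a number 2.9 percentage points higher from compound 2 to compound 4 (within the scatter) and a number 9.1 percentage points higher from compound 1 to compound 4 (within the scatter). Within the data shown here, the position, meta to a large group, has now taken hydrogen, chloro, methoxy and trifluoromethyl, and no step among the four goes beyond the scatter. Nothing measured gives a reason for these small steps. The compounds shown leave open whether an amine or a carboxylic acid on this carbon would give a step beyond the scatter, and what any of these groups would do on other carbons of the same ring.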